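Hydroxy for fluoro on the anilino ring of compound 2

A few compounds are considered here, and "the series" means these few. Any claim that something is new, unique, unknown or untested is made for them only; others in the source may bear on it.

Compound 1 `CC(C)c1ccc(-c2nc(SCc3cn(CC(=O)NC(=O)Nc4ccccn4)nn3)nc(Nc3ccc(F)cc3)c2C#N)cc1` is the reference of this small set; in a functional assay on MGC-803 cells (Homo sapiens) for inhibition, read by MTT assay, with a stated time of 72 h (on this read-out higher numbers stand for weaker inhibition and lower numbers for stronger inhibition), compound 1 gives 17500 nM. Compound 2 `CC(C)c1ccc(-c2nc(SCc3cn(CC(=O)NC(=O)Nc4ccccn4)nn3)nc(Nc3ccccc3F)c2C#N)cc1` carries 2-fluorophenyl in place of 4-fluorophenyl on a nitrogen on an aromatic ring. In this assay compound 2 reaches only the limit > 64000 nM, so no number is known for it. The step of an at least 3.6-fold higher number from compound 1 to compound 2 (0.56 log units; beyond the scatter) is thus bounded by the limit of > 64000 nM in this assay, at which 1 of the 2 values shown sits. Compound 3 `CC(C)c1ccc(-c2nc(SCc3cn(CC(=O)NC(=O)Nc4ccccn4)nn3)nc(Nc3ccccc3O)c2C#N)cc1` differs from compound 2 by hydroxy in place of fluoro on an aromatic carbon. Within the data shown here, no measured step concerns this change; the single step from compound 1 to compound 2 moves the fluoro around the ring and says nothing about a hydroxy. Compound 2 stands at the limit, which leaves the starting number open. The expected step of an at least 1.0-fold lower number from compound 2 to compound 3 (0.02 log units; that floor lies within the scatter) is therefore taken as none beyond the scatter. Compound 3 is expected at 60000 nM, with a range from 15000 nM to 200000 nM and a fair chance that only a limit is reported again.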

Compound 3, half-maximal inhibitory concentration: 16400 nM
Compound 3: middle estimate off by 3.7-fold (0.56 log units), on the high side, within the range that was stated.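

In this assay, hydroxy in place of fluoro on this aromatic carbon gives an at least 3.9-fold lower number from compound 2 to compound 3 (0.59 log units; beyond the scatter), so this position can carry a measurable number. Going by these compounds, compound 2 has only a limit, so the size of that step stays open: the limit of > 64000 nM in this assay, at which 1 of the 3 values shown sits. The step from the reference reads a 1.1-fold lower number from compound 1 to compound 3 (0.03 log units; within the scatter), so 2-hydroxyphenyl and 4-fluorophenyl on this nitrogen cannot be told apart here, and the loss seen with 2-fluorophenyl does not extend to every group in this place on the ring.

On these data alone, whether this recovery is specific to hydroxy remains open; a methoxy or an amino group on the same aromatic carbon would test that. Also open, as far as these compounds go, is how a 4-hydroxyphenyl group on the same nitrogen would compare with the 2-hydroxyphenyl group.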